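Phenyl in Place of Thiophen-2-yl: Compound 2 to Compound 3

The source may hold more compounds than are shown below. What is called first, only, known or untested is meant among the compounds shown, and "the series" means these compounds.

Of the compounds shown here, two on a shared core have been measured so far. Compound 1 `CCCSc1nc(N/N=C(\C)c2ccccc2O)c2nnn(Cc3ccco3)c2n1` gives 5760 nM in a functional assay on ECa-109 cells (Homo sapiens) for antiproliferative activity, read by MTT assay, with a stated time of 72 h; a higher number here means a weaker inhibitor, a lower number a stronger inhibitor. Compound 2 `CCCSc1nc(N/N=C/c2cccs2)c2nnn(Cc3ccccc3)c2n1` differs from compound 1 in more than one place, so the pair shows only a number for one and a limit for the other. In this assay compound 2 gives > 64000 nM, which is a limit of the assay and not a number. Compound 2 thus stands at the limit of > 64000 nM in this assay, at which 1 of the 2 values shown sits, with no value of its own on the scale.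

Compound 3 `CCCSc1nc(N/N=C/c2ccccc2)c2nnn(Cc3ccccc3)c2n1` is not yet measured. It differs from compound 2 by phenyl in place of thiophen-2-yl on a carbon with a double bond to nitrogen. For the measured compounds named here, no step between measured compounds carries this change, so nothing measured fixes its size. Because compound 2 already sits at the limit of > 64000 nM in this assay, at which 1 of the 2 values shown sits, only a large gain in potency could yield a number, and any loss would stay hidden. The writer therefore expects compound 3 to remain weak in this assay, with the step estimated as a step that the limit leaves unreadable from compound 2 to compound 3. Compound 3 is estimated at 70000 nM, within a range from 20000 nM to 200000 nM, and a further limit rather than a number is the likelier outcome.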

Compound 3, half-maximal inhibitory concentration: > 64000 nM
Compound 3 was reported as a limit; the forecaster's own chance of this, stated with the estimate: 60%; the middle value does not contradict the limit.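

In this assay compound 3 gives > 64000 nM, which is a limit of the assay and not a number. No step from compound 2 to compound 3 can be read, because both compounds stand at a limit: the limit of > 64000 nM in this assay, at which 2 of the 3 values shown sit.

The compounds shown leave open whether phenyl and thiophen-2-yl differ at all in potency on this core.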